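Chain lengthening from compound 3 to compound 4

The source may report more compounds than this note shows. Statements on the series, on what has been measured and on what is new or still open speak of the compounds shown alone.

Going by the values given here, compound 3 `COc1cc2nc(N(C)CCCCCN(C)C(=O)c3ccco3)nc(N)c2cc1OC` gives 1.48 nM in a functional assay for antagonist activity at Adrenergic receptor alpha-1 (Rattus norvegicus) (on this read-out higher numbers stand for weaker binding and lower numbers for tighter binding), the lowest of the three numbers so far. Compound 2 `COc1cc2nc(N(C)CCCCN(C)C(=O)c3ccco3)nc(N)c2cc1OC` gives 7.08 nM, and compound 1 `COc1cc2nc(NCCCCCCCCNC(=O)c3ccco3)nc(N)c2cc1OC` gives 60.3 nM. The change to compound 4 `COc1cc2nc(N(C)CCCCCCCN(C)C(=O)c3ccco3)nc(N)c2cc1OC` is 2-(((furan-2-yl)carbonyl)(methyl)amino)ethyl in place of ((furan-2-yl)carbonyl)(methyl)amino on a saturated chain carbon, five bonds along the chain from a nitrogen on an aromatic ring. Among the compounds with values here, the only step that bears on it is the lengthening of the chain by one carbon, a 4.8-fold lower number from compound 2 to compound 3 (0.68 log units; beyond the scatter). Compound 4 lengthens the chain by two more carbons, so a further fall in this assay is expected, though a smaller one than that single step, as compound 1 with its longer chain gives 60.3 nM but differs in more than one place. Compound 4 is therefore estimated at 0.9 nM, range 0.3 nM to 4 nM, a step of a 1.6-fold lower number from compound 3 to compound 4 (0.22 log units; within the scatter).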

Compound 4, dissociation constant: 2.51 nM
The estimate for compound 4 lay 2.8-fold (0.45 log units) below the measured number; low and high end bracket the measured number.
By their numbers in this assay, from the lowest: compounds 3 and 4 (each within the scatter of the next); then compound 2; then compound 1.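

In this assay, 2-(((furan-2-yl)carbonyl)(methyl)amino)ethyl in place of ((furan-2-yl)carbonyl)(methyl)amino at this chain carbon gives a 1.7-fold higher number from compound 3 to compound 4 (0.23 log units; within the scatter) and so cannot be told apart from no change. The earlier lengthening, a 4.8-fold lower number from compound 2 to compound 3 (0.68 log units; beyond the scatter) and beyond the scatter, therefore finds no measurable continuation in this further extension. No supporting data explain this result.

Still open, as far as these compounds go, is whether a longer chain than that of compound 4 stays within the scatter of compound 3. Also open, from the compounds shown here alone, is whether an amine or a carboxylic acid in place of the furan-2-yl carbonyl group is tolerated at this chain length.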